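Fluoro for Methoxy in a Cytotoxicity Series

A few compounds are considered here, and "the series" means these few. Any claim that something is new, unique, unknown or untested is made for them only; others in the source may bear on it.

Compound 1 `COc1cccc(-c2oc3ccc(NC(C)=O)cc3c(=O)c2O)c1` and compound 2 `CC(=O)Nc1ccc2oc(-c3cccc(F)c3)c(O)c(=O)c2c1` share one core and differ only by fluoro in place of methoxy on an aromatic carbon. In an ADME assay on THP-1 cells (Homo sapiens) for cytotoxicity, read by flow cytometry and propidium iodide staining, with a stated time of 72 h (a lower number here means a stronger inhibitor, a higher number a weaker inhibitor), compound 1 gives 50000 nM, while compound 2 gives 36000 nM, so the change made a 1.4-fold lower number from compound 1 to compound 2 (0.14 log units; within the scatter). Compound 3 `COc1ccccc1-c1oc2ccc(N)cc2c(=O)c1OC` sits on a different core, and the difference between the two cores is not broken down here; in this assay compound 3 gives 116000 nM. Compound 4 `COc1c(-c2ccccc2F)oc2ccc(N)cc2c1=O` differs from compound 3 by fluoro in place of methoxy on an aromatic carbon. Within the data shown here, this is the same kind of change as the one between compound 1 and compound 2, yet the place is not identical: meta to a large group in the first pair, ortho to a large group in the second. Among the measured compounds shown here, a step of a 1.3-fold lower number from compound 3 to compound 4 (0.11 log units; within the scatter) is expected, resting on the single measured example, a 1.4-fold lower number from compound 1 to compound 2 (0.14 log units; within the scatter). Compound 4 is therefore estimated at 90000 nM, likely between 40000 nM and 200000 nM.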

Compound 4, half-maximal inhibitory concentration: > 125000 nM
Compound 4 ended at the assay's limit (the forecaster's own chance of this, stated with the estimate: 25%); at least 1.3-fold (0.14 log units) between middle value and limit.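

In this assay compound 4 gives > 125000 nM, which is a limit of the assay and not a number. The step therefore gives only a floor: an at least 1.0-fold higher number from compound 3 to compound 4 (0.03 log units; that floor lies within the scatter). Set beside the earlier pair, this does not show that fluoro in place of methoxy carries over from one core to the other, nor does it show that the change behaves differently on the two cores: the same change on two cores in this assay, a 1.4-fold lower number (0.14 log units; within the scatter) from compound 1 to compound 2 and an at least 1.0-fold higher number (0.03 log units; that floor lies within the scatter) from compound 3 to compound 4; the limit leaves it open whether they differ.

The compounds shown leave open what a chloro or a nitrile group in place of methoxy would give on either core. They also leave open whether the change would read the same if both cores carried it at the same place on the ring.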